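Replacing the carboxyethenyl amide: the chlorothiazolyl analogue

This account rests on a few compounds, and the source may have more. Where it says the series, first, only, none or still open, it means among the compounds named here.

This account follows the step from compound 2 to compound 4. Compound 2 `O=C(O)/C=C/C(=O)Nc1cccc(-c2nc3ccccc3s2)c1` gives the lowest of the three numbers in an ADME assay for permeability, using PAMPA (on this read-out higher numbers stand for higher permeability and lower numbers for lower permeability), at 4 10^-6 cm/s. Compound 1 `C=CC(=O)Nc1cccc(-c2nc3ccccc3s2)c1` gives 797 10^-6 cm/s in this assay, and compound 3 `O=C(Nc1cccc(-c2nc3ccccc3s2)c1)c1ccc(Cl)nc1Cl` gives 104 10^-6 cm/s. The change from compound 1 is a 200-fold lower number from compound 1 to compound 2 (2.30 log units; beyond the scatter), and the change onward to compound 3 is a 26-fold higher number from compound 2 to compound 3 (1.41 log units; beyond the scatter); the direct comparison of compound 1 and compound 3 is a 7.7-fold lower number from compound 1 to compound 3 (0.88 log units; beyond the scatter).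

Compound 4 `O=C(Nc1cccc(-c2nc3ccccc3s2)c1)c1cnc(Cl)s1` differs from compound 2 by 2-chloro-1,3-thiazol-5-yl in place of 2-carboxyethenyl on a carbonyl carbon. Among the compounds with values here, the step that bears most on this is the one to compound 3, since it too replaces the 2-carboxyethenyl group on the carbonyl carbon with a chlorinated aromatic ring, and that step was a 26-fold higher number from compound 2 to compound 3 (1.41 log units; beyond the scatter). The chlorothiazolyl amide of compound 4 is therefore expected to move by a similar large amount in the same direction, giving a 25-fold higher number from compound 2 to compound 4 (1.40 log units; beyond the scatter). In this assay compound 4 is estimated at 100 10^-6 cm/s, with a range from 35 10^-6 cm/s to 300 10^-6 cm/s.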

Compound 4, apparent permeability: 133 10^-6 cm/s
Estimate against measurement, compound 4: 1.3-fold (0.12 log units) below, within the range that was stated.
By their numbers in this assay, from the lowest: compound 2; then compounds 3 and 4 (each within the scatter of the next); then compound 1.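

In this assay, the large rise seen with the 2,6-dichloropyridin-3-yl group is not confined to that ring: the five-membered 2-chloro-1,3-thiazol-5-yl group also gives a 33-fold higher number from compound 2 to compound 4 (1.52 log units; beyond the scatter). The two chlorinated aromatic rings cannot be told apart at this carbonyl carbon, with a 1.3-fold higher number from compound 3 to compound 4 (0.11 log units; within the scatter). Neither matches the vinyl group, as a 6.0-fold lower number from compound 1 to compound 4 (0.78 log units; beyond the scatter) shows, so the new ring adds a second case in which an aromatic replacement recovers much, but not all, of the gap opened by a 200-fold lower number from compound 1 to compound 2 (2.30 log units; beyond the scatter).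

Nothing measured here explains these steps. The compounds shown leave open whether the chlorine matters on the thiazole ring, which an unsubstituted thiazol-5-yl amide would test, and whether a methyl ester in place of the carboxylic acid of compound 2 would change the number.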